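Working notes: one added hydroxy on compound 3

The source may report more compounds than this note shows. Statements on the series, on what has been measured and on what is new or still open speak of the compounds shown alone.

Measured in a toxicity assay (RAW264.7 cells) for cytotoxicity, with Mus musculus as the target, read by MTT assay, with a stated time of 4 h; a lower number here means a stronger inhibitor, a higher number a weaker inhibitor (a limit of the assay in every case, not a number)
- compound 1 `O=c1oc2ccc(O)cc2cc1-c1ccccc1O` gives > 100000 nM (a limit)
- compound 2 `O=c1oc2ccc(O)cc2cc1-c1cccc(O)c1` gives > 100000 nM (a limit)
- compound 3 `O=c1oc2c(O)cccc2cc1-c1cccc(O)c1` gives > 100000 nM (a limit)

Compound 3 sits with the whole measured set at the limit of > 100000 nM in this assay, at which 3 of the 3 values shown sit, and no number places it against the others. Its own entry of > 100000 nM in this assay is a limit and not a number.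

Compound 4 `O=c1oc2c(O)cccc2cc1-c1ccc(O)c(O)c1` differs from compound 3 by hydroxy in place of hydrogen on an aromatic carbon, ortho to a hydroxy group and para to a large group (hydroxy in place of hydrogen on an aromatic carbon). For the measured compounds named here, no measured pair isolates a single change, so the series gives no size for such a step. No shift beyond the scatter is expected in this assay and the estimated change is small (a number no higher from compound 3 to compound 4 (the limit leaves the size open)). For compound 4 the estimate is 100000 nM with an expected range from 40000 nM to 200000 nM and a report of only a limit is the likeliest outcome.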

Compound 4, half-maximal inhibitory concentration: 115000 nM
The estimate for compound 4 lay 1.2-fold (0.06 log units) below the measured number; low and high end bracket the measured number.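

No step can be read from compound 3 to compound 4, because compound 3 carries a limit and not a number: the limit of > 100000 nM in this assay, at which 3 of the 4 values shown sit.

The compounds shown leave open what size of change, if any, hydroxy in place of hydrogen on an aromatic carbon brings in this assay.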